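Acetyl on the side-chain oxygen: expectation for compound 4

This account rests on a few compounds, and the source may have more. Where it says the series, first, only, none or still open, it means among the compounds named here.

Compound 1 `CC(=O)OCCc1c(C)nc(Cl)nc1Cl`: > 100000 nM
Compound 2 `COc1nc(C)c(CCO)c(OC)n1`: > 100000 nM
Compound 3 `COc1nc(Cl)nc(C)c1CCO`: > 100000 nM

In a functional assay on SW-620 cells (Homo sapiens) for antiproliferative activity, read by MTT assay, with a stated time of 24 h (on this read-out higher numbers stand for weaker inhibition and lower numbers for stronger inhibition), compound 2 gives only a limit, > 100000 nM, and not a number. Compound 3 in this assay gives > 100000 nM, likewise a limit. Within the data shown here, the one recorded step, a step that the two limits leave unreadable from compound 2 to compound 3, therefore cannot be sized. The same holds across the whole set: the limit of > 100000 nM in this assay, at which 3 of the 3 values shown sit. Compound 1 also returns only a limit, and it already carries the acetoxy group on its side chain.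

Compound 4 `COc1nc(C)c(CCOC(C)=O)c(OC)n1` differs from compound 2 by acetyl in place of hydrogen on an oxygen on a saturated carbon. Cut one bond further out this reads hydroxy to acetoxy, hydroxymethyl to acetoxymethyl. Among the measured compounds shown here, no measured step bears directly on this change; the step from compound 2 to compound 3 is unreadable, and compound 1 offers no number to compare with. With every recorded value sitting at the limit (the limit of > 100000 nM in this assay, at which 3 of the 3 values shown sit), no step in either direction can be read, and none is expected here. Compound 4 is expected to return a limit in this assay as well. The expected step from compound 2 to compound 4 is accordingly a step that the limit leaves unreadable from compound 2 to compound 4. For compound 4 the estimate is 250000 nM, in the range 100000 nM to 1000000 nM.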

Compound 4, half-maximal inhibitory concentration: 44000 nM
The estimate for compound 4 lay 5.7-fold (0.75 log units) above the measured number; measured number outside the range, below it.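

In this assay, acetyl in place of hydrogen on an oxygen on a saturated carbon gives the only number among the compounds shown, with an at least 2.2-fold lower number from compound 2 to compound 4 (0.35 log units; beyond the scatter). On the core of compound 2, hydroxy to acetoxy therefore moves the read-out off the limit and beyond the usual scatter, whereas the step for chloro in place of methoxy on an aromatic carbon cannot be read. The true size of the new step stays unknown, and it is a bound only because it starts from a limit: the limit of > 100000 nM in this assay, at which 3 of the 4 values shown sit.

Compound 1 also carries the acetoxy group and gives > 100000 nM, which is a limit, and since it differs from compound 4 in more than one place, it cannot show whether the effect of acetyl depends on the rest of the core. From the compounds shown here alone, it also remains open whether the step is specific to acetyl or extends to a longer acyl chain such as butyryl, or to an amine in place of the hydroxy group of compound 2.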